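Swapping a nitro group for an amino group

A few compounds are considered here, and "the series" means these few. Any claim that something is new, unique, unknown or untested is made for them only; others in the source may bear on it.

In a functional assay on the whole organism with Mus musculus as the target (on this read-out higher numbers stand for an effect only at larger amounts of compound and lower numbers for an effect already at smaller amounts), compound 3 (`COc1cc2c(cc1OC)C(c1cccc([N+](=O)[O-])c1)=NNC(=O)C2`) gives no exact number, only a limit of > 120 umol/kg. As far as these compounds go, this is the limit of > 120 umol/kg in this assay, at which 1 of the 3 values shown sits, so the true position of compound 3 remains open on the high side.

Compound 2 (`COc1cc2c(cc1OC)C(c1ccccc1)=NNC(=O)C2`) has the same core without the nitro group and gives 33.9 umol/kg. Adding that group produced an at least 3.5-fold higher number from compound 2 to compound 3 (0.54 log units; beyond the scatter). Among the measured compounds shown here, this is the only measured step in which one group alone changes.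

Compound 4 (`COc1cc2c(cc1OC)C(c1cccc(N)c1)=NNC(=O)C2`) has amino in place of nitro on an aromatic carbon. The group sits on a six-membered aromatic ring of carbon only, meta to a large group. For the measured compounds named here, no measured step makes exactly this swap, so the expectation rests on two neighbours. Removing the nitro group would undo the change seen in an at least 3.5-fold higher number from compound 2 to compound 3 (0.54 log units; beyond the scatter), which points back towards the value of compound 2. Compound 1 (`COc1cc2c(cc1OC)C(c1cccc(N)c1)=NN=C(S)C2`) carries the same amino group on a core that differs elsewhere, and it gives 18.8 umol/kg.

A clear move to lower numbers is therefore expected, and the estimated change is an at least 5.4-fold lower number from compound 3 to compound 4 (0.73 log units; beyond the scatter). For compound 4 the estimated value is 22 umol/kg, with an expected range from 8 umol/kg to 60 umol/kg.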

Compound 4, dose for half-maximal effect: 19.3 umol/kg
For compound 4 the middle estimate is 1.1-fold (0.06 log units) above the measured one; measured number inside the range.
By their numbers in this assay, from the lowest: compounds 1, 4 and 2 (each within the scatter of the next). At a limit, above all of these: compound 3.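

Amino in place of nitro on this aromatic carbon gives an at least 6.2-fold lower number from compound 3 to compound 4 (0.79 log units; beyond the scatter) in this assay, the first step shown that swaps one group directly for another at this place while the rest of the molecule stays the same. The true size of that step remains unknown because compound 3 stands at a limit, so the printed size is only a minimum: the limit of > 120 umol/kg in this assay, at which 1 of the 4 values shown sits.

The comparison with hydrogen adds a second point: amino in place of hydrogen gives a 1.8-fold lower number from compound 2 to compound 4 (0.24 log units; within the scatter), whereas nitro in place of hydrogen gives an at least 3.5-fold higher number from compound 2 to compound 3 (0.54 log units; beyond the scatter), so at this place the amino compound cannot be told apart from the compound carrying hydrogen, while the nitro compound clearly differs from it.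

With only hydrogen, nitro and amino shown at this place, these compounds cannot show whether the move away from compound 2 is peculiar to the nitro group. As far as these compounds go, a hydroxyl group, a methyl group or a dimethylamino group on the same carbon could stay close to compound 2 or could shift the number as nitro does, and that remains open.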